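A few compounds are considered here, and "the series" means these few. Any claim that something is new, unique, unknown or untested is made for them only; others in the source may bear on it.

Three compounds sharing one core have been run in a functional assay on the whole organism with Rattus norvegicus as the target, at a dose of 20 mg/kg by the intraperitoneal route; on this read-out lower numbers stand for less inhibition and higher numbers for more inhibition at the one dose given (going by the name of the read-out). Compound 2 `Nc1nc(N)nc(-c2ccc(F)cc2)n1` gives 84%. Compound 1 `Nc1nc(N)nc(-c2cccc(C(F)(F)F)c2)n1` gives 81%, a number that lies within the usual scatter of the result for compound 2, so the two cannot be told apart. Compound 3 `Nc1nc(N)nc(-c2cc(Br)ccc2Br)n1` gives 43%, a number well beyond the scatter below that of compound 2. Compound 2 thus stands at the top of the numbers seen so far, with compound 1 effectively alongside it and compound 3 clearly lower.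

Compound 4 `Nc1nc(N)nc(-c2ccc([N+](=O)[O-])cc2)n1` has not yet been measured in this assay. It differs from compound 2 in one place: nitro in place of fluoro on an aromatic carbon. Going by the values given here, no pair of measured compounds differs in a single place, so there is no measured step to lean on for this change. Among the compounds with values here, the only guide is that both single-substituted analogues, compound 1 and compound 2, sit high, while the twice-substituted compound 3 sits far lower.

Compound 4 is expected to give about 74% in this assay, within a range from 50% to 90%. The step expected from a number 10 percentage points lower from compound 2 to compound 4 (within the scatter) is estimated to be a modest decrease, possibly no further than the scatter.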

Compound 4, a percentage reported as inhibition, in the whole organism at one dose (the size of the read-out at that dose, not a potency) in the Rattus norvegicus assay: 41%
For compound 4 the middle estimate is 33 percentage points above the measured one; the measured number lies below the stated range.
By their numbers in the Rattus norvegicus assay, from the lowest: compounds 4 and 3 (each within the scatter of the next); then compounds 1 and 2 (each within the scatter of the next).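

Nitro in place of fluoro on this aromatic carbon, para to a group of 8 heavy atoms, gives the first single-place step in the Rattus norvegicus assay (a number 43 percentage points lower from compound 2 to compound 4 (beyond the scatter)), so one substituent at this position does not by itself keep the number high. In a physicochemical assay for lipophilicity (a lower number here means a more polar compound, a higher number a more lipophilic compound), compound 2 gives 1.61 and compound 4 gives 1.6 (a number 0.01 log units lower from compound 2 to compound 4 (within the scatter)), so these two compounds cannot be told apart on this partition coefficient, even though they are far apart in the whole-organism read-out. Nothing available explains the large step.

From the compounds shown here alone, whether the fall belongs to nitro alone or extends to other groups on this carbon remains open. An amine, a carboxylic acid or a methoxy group here would begin to settle that.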